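A Phenyl Added to the Core of Compound 3

A few compounds are considered here, and "the series" means these few. Any claim that something is new, unique, unknown or untested is made for them only; others in the source may bear on it.

Of the compounds shown here, three sharing one core have been tested in a functional assay on HEK293 cells for antagonist activity at transient receptor potential cation channel subfamily V member 1 (Homo sapiens), read by calcium flux; a higher number here means a weaker inhibitor, a lower number a stronger inhibitor. Compound 1 `FC(F)(F)c1ccc(Nc2ncnc3sc(Nc4c(Cl)cccc4Cl)nc23)cc1` gives 12 nM, compound 2 `FC(F)(F)c1cccc(Nc2ncnc3sc(Nc4c(Cl)cccc4Cl)nc23)c1` gives 206 nM, and compound 3 `FC(F)(F)c1ccc(Nc2ncnc3sc(Nc4c(Cl)cccc4Cl)nc23)cc1Cl` gives 21 nM, the second highest of the three numbers, close to compound 1 and far from compound 2. Among the compounds with values here, the only measured step between direct neighbours, a 1.8-fold higher number from compound 1 to compound 3 (0.24 log units; within the scatter), concerns a chloro group on the outer ring. Within the data shown here, compound 4 `FC(F)(F)c1ccc(Nc2nc(-c3ccccc3)nc3sc(Nc4c(Cl)cccc4Cl)nc23)cc1Cl` differs from compound 3 by phenyl in place of hydrogen on an aromatic carbon, a change on the core between two ring nitrogen atoms; no measured step addresses such a change, so the direction is uncertain. The expected step in this assay is a 1.7-fold higher number from compound 3 to compound 4 (0.22 log units; within the scatter), within the scatter or modestly weaker. Compound 4 is estimated at 35 nM, ranging from 10 nM to 120 nM.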

Compound 4, half-maximal inhibitory concentration: 539 nM
The estimate for compound 4 lay 15-fold (1.19 log units) below the measured number; the measured number lies above the stated range.
By their numbers in this assay, from the lowest: compounds 1 and 3 (each within the scatter of the next); then compound 2; then compound 4.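

In this assay, the carbon between two ring nitrogen atoms proves sensitive to change: phenyl in place of hydrogen there gives a large loss of inhibition (a 26-fold higher number from compound 3 to compound 4 (1.41 log units; beyond the scatter)). Within the data shown here, the only earlier step between direct neighbours, a chloro group on the outer ring, stayed within the scatter, so this is the first sign that a change on the core can matter far more. Nothing available explains the size of this loss. On these data alone, whether a methyl group or an amine at this carbon would also weaken inhibition remains open, so the result cannot yet be generalised beyond phenyl.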